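Changing the group on a sulfonyl sulfur

The source may hold more compounds than are shown below. What is called first, only, known or untested is meant among the compounds shown, and "the series" means these compounds.

Compound 1 `O=C(NCc1ccc(S(=O)(=O)c2cc(F)cc(F)c2)cc1)N1Cc2ccncc2C1` gives 8 mL/min/kg in an ADME assay on microsomes from liver (Homo sapiens) for pharmacokinetics, read by LC-MS, with a stated time of 60 min, tested at 1 uM; a higher number here means faster removal of the compound, a lower number slower removal
Compound 2 `CCC(=O)N1CCC(S(=O)(=O)c2ccc(CNC(=O)N3Cc4ccncc4C3)cc2)CC1` gives 11 mL/min/kg

These two values lie within the scatter of each other, so compound 2 stands no clear distance from compound 1. Compound 3 `CN1CCN(S(=O)(=O)c2ccc(CNC(=O)N3Cc4ccncc4C3)cc2)CC1` has not yet been measured. It differs from compound 2 by having 4-methylpiperazin-1-yl in place of 1-propanoylpiperidin-4-yl on a sulfonyl sulfur, and 4-methylpiperazin-1-yl in place of 1-propanoylpiperidin-4-yl on a sulfonyl sulfur gives the count of that change. Among the measured compounds shown here, the one measured step that bears on this, also a swap on a sulfonyl sulfur, is a 1.4-fold higher number from compound 1 to compound 2 (0.14 log units; within the scatter) and so no step beyond the scatter is expected in this assay here. The expected outcome is a 1.1-fold lower number from compound 2 to compound 3 (0.04 log units; within the scatter) and nothing larger. For compound 3 the estimated clearance is 10 mL/min/kg with an expected range from 5 mL/min/kg to 20 mL/min/kg in this measurement.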

Compound 3, clearance: 9 mL/min/kg
Compound 3: the middle estimate sits 1.1-fold (0.05 log units) above what was measured; the range from low to high includes it.
By their numbers in this assay, from the lowest: compounds 1, 3 and 2 (each within the scatter of the next).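

Three quite different groups on the sulfonyl sulfur now give clearance values that cannot be told apart in this assay: 4-methylpiperazin-1-yl matches 1-propanoylpiperidin-4-yl (a 1.2-fold lower number from compound 2 to compound 3 (0.09 log units; within the scatter)) and also 3,5-difluorophenyl (a 1.1-fold higher number from compound 1 to compound 3 (0.05 log units; within the scatter)). Across these three compounds, then, swapping an aromatic ring for either of two non-aromatic rings leaves no step beyond the scatter. No measurement available here accounts for this.

Still open, from the compounds shown here alone, is whether a carboxylic acid or a longer alkyl chain on the sulfonyl sulfur would give a step beyond the scatter.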